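Two Inactive Enantiomers and a Desmethyl Analogue to Come

This account rests on a few compounds, and the source may have more. Where it says the series, first, only, none or still open, it means among the compounds named here.

Compound 1 `C[C@H]1N=C2C[C@H]3C[C@H](C3(C)C)[C@@]2(C)OC1=O` — > 1800000 nM (a limit)
Compound 2 `C[C@@H]1N=C2C[C@@H]3C[C@@H](C3(C)C)[C@]2(C)OC1=O` — > 2000000 nM (a limit)

In an ADME assay on McCoy cells (Mus musculus) for antiproliferative activity, read by sulforhodamine B assay, with a stated time of 48 h (a higher number here means a weaker inhibitor, a lower number a stronger inhibitor), compound 1 is reported only as a limit of the assay, > 1800000 nM. Compound 2 is likewise reported only as a limit, > 2000000 nM. The step that the two limits leave unreadable from compound 1 to compound 2 therefore cannot be read, even though the fact that compounds 1 and 2 differ only in the configuration as drawn makes the two compounds mirror images of one another. Compound 2 thus stands on a limit, with no number behind it, and the other value shown is a limit as well (the limit of > 1800000 nM in this assay, at which 1 of the 2 values shown sits).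

Compound 3 `CC1(C)[C@@H]2CC3=NCC(=O)O[C@@]3(C)[C@H]1C2` differs from compound 2 by hydrogen in place of methyl on a saturated ring carbon. For the measured compounds named here, the only measured step bears on this change solely as two limits (the limit of > 2000000 nM in this assay, at which 1 of the 2 values shown sits), so no size of step can be drawn from it. Compound 3 is therefore expected to remain at the limit, with an estimated value of 2000000 nM (range 500000 nM to 6000000 nM). The expected step of a number no higher from compound 2 to compound 3 (the limit leaves the size open) is none beyond the scatter.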

Compound 3, half-maximal inhibitory concentration: > 900000 nM
Compound 3 ended at the assay's limit; the forecaster's own chance of this, stated with the estimate: 85%; the middle value lies beyond the limit too.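

In this assay compound 3 gives > 900000 nM, which is a limit of the assay. For the compounds shown here, as compound 2 and compound 3 both stand on limits, no step between them can be read. The compounds shown leave open what hydrogen in place of methyl on a saturated ring carbon does to antiproliferative activity, and at what concentration, if any, compound 1, compound 2 or compound 3 would inhibit.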